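A few compounds are considered here, and "the series" means these few. Any claim that something is new, unique, unknown or untested is made for them only; others in the source may bear on it.

In a functional assay on MCF7 cells (Homo sapiens) for inhibition, read by MTT assay, with a stated time of 5 days (on this read-out higher numbers stand for weaker inhibition and lower numbers for stronger inhibition), compound 1 `Cc1cc(Nc2nc(NCc3ccccc3Br)nc3[nH]ncc23)n[nH]1` gives 14100 nM, compound 2 `Cc1cc(Nc2nc(NCc3cccc(Cl)c3)nc3[nH]ncc23)n[nH]1` gives 5620 nM and compound 3 `Cc1cc(Nc2nc(NCc3ccc(F)cc3F)nc3[nH]ncc23)n[nH]1` gives 670 nM, the lowest of the three numbers. Compound 4 `Cc1cc(Nc2nc(NCc3ccc(C#N)cc3)nc3[nH]ncc23)n[nH]1` is not yet measured. It differs from compound 3 by 4-cyanophenyl in place of 2,4-difluorophenyl on a saturated chain carbon bound to a nitrogen on an aromatic ring, with 4-cyanophenyl in place of 2,4-difluorophenyl. The measured steps at this same place are a 2.5-fold lower number from compound 1 to compound 2 (0.40 log units; beyond the scatter), a 21-fold lower number from compound 1 to compound 3 (1.32 log units; beyond the scatter) and an 8.4-fold lower number from compound 2 to compound 3 (0.92 log units; beyond the scatter). None of them involves 4-cyanophenyl, but the last two show the other aryl groups sitting higher than compound 3. A modest expected step toward a higher number follows in this assay, estimated as a 4.5-fold higher number from compound 3 to compound 4 (0.65 log units; beyond the scatter). For compound 4 the estimate is 3000 nM, with an expected range of 800 nM to 11000 nM.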

Compound 4, half-maximal inhibitory concentration: 6060 nM
Estimate against measurement, compound 4: 2.0-fold (0.31 log units) below, and the stated range covers the measured number.
By their numbers in this assay, from the lowest: compound 3; then compounds 2 and 4 (each within the scatter of the next); then compound 1.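

In this assay, 4-cyanophenyl does not keep the low number of 2,4-difluorophenyl at this saturated chain carbon, with a 9.0-fold higher number from compound 3 to compound 4 (0.96 log units; beyond the scatter). It matches 3-chlorophenyl, with a 1.1-fold higher number from compound 2 to compound 4 (0.03 log units; within the scatter), and still improves on 2-bromophenyl, with a 2.3-fold lower number from compound 1 to compound 4 (0.37 log units; beyond the scatter), so among these four aryl groups only 2,4-difluorophenyl stands apart at the low end. Nothing available bears on why these aryl groups differ. The compounds shown leave open how unsubstituted phenyl would compare, and whether an amine or a carboxylic acid in place of the nitrile would change the number.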